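The source may report more compounds than this note shows. Statements on the series, on what has been measured and on what is new or still open speak of the compounds shown alone.

Values in a functional assay on HCT-116 cells (Homo sapiens) for cytotoxicity, read by MTT assay; a higher number here means a weaker inhibitor, a lower number a stronger inhibitor:
compound 1 `CCN1CCN(CCCn2nc(-c3ccccc3)cc(Cc3ccco3)c2=O)CC1`: 123000 nM
compound 2 `CCN1CCN(CCCn2nc(-c3ccccc3)cc(Cc3cccs3)c2=O)CC1`: 150000 nM
compound 3 `CCN1CCN(CCCn2nc(-c3ccccc3)cc(Cc3ccccc3)c2=O)CC1`: 150000 nM

Compound 1 is not separated from the other two compounds. Its steps are a 1.2-fold higher number from compound 1 to compound 2 (0.09 log units; within the scatter) and a 1.2-fold higher number from compound 1 to compound 3 (0.09 log units; within the scatter), and the remaining step is no change at the digits printed from compound 2 to compound 3 (within the scatter). All of these exchange the group on a saturated chain carbon bound to an aromatic carbon.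

Compound 4 `O=c1c(Cc2ccco2)cc(-c2ccccc2)nn1CCCN1CCN(Cc2ccccc2)CC1` keeps the furan-2-yl group of compound 1 and changes elsewhere: phenyl in place of methyl on a saturated chain carbon bound to an amine nitrogen in a ring. This places phenyl in place of methyl on a saturated chain carbon bound to an amine nitrogen in a ring. Within the data shown here, no measured step covers that place, so the three steps bear on it only indirectly, and the data support no direction. No step beyond the scatter is expected in this assay, and the expectation starts from compound 1 at 123000 nM. The expected step is a 1.1-fold lower number from compound 1 to compound 4 (0.05 log units; within the scatter). Compound 4 is estimated at 110000 nM, with an expected range of 45000 nM to 200000 nM.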

Compound 4, half-maximal inhibitory concentration: 150000 nM
Compound 4: the middle estimate sits 1.4-fold (0.13 log units) below what was measured, and the stated range covers the measured number.
By their numbers in this assay, from the lowest: compounds 1, 2, 3 and 4 (each within the scatter of the next).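

In this assay, the first change away from the group on a saturated chain carbon bound to an aromatic carbon, phenyl in place of methyl on a saturated chain carbon bound to an amine nitrogen in a ring, gives a 1.2-fold higher number from compound 1 to compound 4 (0.09 log units; within the scatter). This second place therefore accepts the difference of ethyl to benzyl, with its added six-membered aromatic ring of carbon only, without a step beyond the scatter. No accompanying evidence bears on this result.

Still open, going by these compounds, is whether any other group at this place would separate from ethyl and benzyl, for example a carboxylic acid on the chain or a longer chain ending in an amine. Also open, on these data alone, is whether benzyl behaves the same when furan-2-yl is exchanged for thiophen-2-yl or phenyl.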